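Working notes: trifluoromethyl for phenyl on compound 2

The source may hold more compounds than are shown below. What is called first, only, known or untested is meant among the compounds shown, and "the series" means these compounds.

Values in a functional assay with Homo sapiens as the target (on this read-out lower numbers stand for stronger inhibition and higher numbers for weaker inhibition), so far
- compound 1 `CC(C)[C@H](NC(=O)COc1cccc2ccccc12)C(=O)N[C@@H](CC(=O)O)C(=O)COc1ccc2ccccc2c1` gives 15900 nM
- compound 2 `CC(C)[C@H](NC(=O)COc1cccc2ccccc12)C(=O)N[C@@H](CC(=O)O)C(=O)COc1ccc(-c2ccccc2)cc1` gives 38700 nM

Compound 2 (38700 nM) holds the higher of the two numbers. Next is compound 3 `CC(C)[C@H](NC(=O)COc1cccc2ccccc12)C(=O)N[C@@H](CC(=O)O)C(=O)COc1ccc(C(F)(F)F)cc1`, with trifluoromethyl in place of phenyl on an aromatic carbon. Among the compounds with values here, one measured step bears on this end of the molecule (a 2.4-fold higher number from compound 1 to compound 2 (0.39 log units; beyond the scatter)), modest and beyond the scatter. Within the data shown here, no measured compound carries trifluoromethyl, so the expectation in this assay is loose: a modest step toward a lower number is expected (a 2.2-fold lower number from compound 2 to compound 3 (0.33 log units; beyond the scatter)). The estimated value for compound 3 is 18000 nM within an expected range (6000 nM to 45000 nM).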

Compound 3, half-maximal inhibitory concentration: 12300 nM
Compound 3: middle estimate off by 1.5-fold (0.17 log units), on the high side, and the stated range covers the measured number.
By their numbers in this assay, from the lowest: compounds 3 and 1 (each within the scatter of the next); then compound 2.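

In this assay trifluoromethyl in place of phenyl on the aromatic carbon gives a clear gain (a 3.1-fold lower number from compound 2 to compound 3 (0.50 log units; beyond the scatter)), so the outer phenyl of the 4-phenylphenyl group is not required at this position. The 4-(trifluoromethyl)phenyl group and naphthalen-2-yl cannot be ordered (a 1.3-fold lower number from compound 1 to compound 3 (0.11 log units; within the scatter)), so a much smaller group with no ring matches the fused aromatic group here. No supporting data bear on the reason for these steps.

From the compounds shown here alone, it remains open whether a methyl group, a nitrile or an amine on the same aromatic carbon would match trifluoromethyl. Going by these compounds, it is also open whether this position can move the number much further from that of compound 3.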